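From 4-methoxyphenyl to 3-methylphenyl on an aromatic carbon

The source may hold more compounds than are shown below. What is called first, only, known or untested is meant among the compounds shown, and "the series" means these compounds.

Values so far in a functional assay on MGC-803 cells (Homo sapiens) for antiproliferative activity, read by MTT assay, with a stated time of 72 h (a higher number here means a weaker inhibitor, a lower number a stronger inhibitor), are these:
- compound 1 `COc1ccc(-c2nc(CNc3ccc(C(=O)NO)cc3)n(-c3ccccc3)n2)cc1` gives > 20000 nM (a limit, not a number)
- compound 2 `O=C(NO)c1ccc(NCc2nc(-c3ccccc3)nn2-c2ccc(Br)cc2)cc1` gives 9300 nM
- compound 3 `Cc1cccc(-n2nc(-c3ccccc3)nc2CNc2ccc(C(=O)NO)cc2)c1` gives 13200 nM

Compound 1 sits at the limit of > 20000 nM in this assay, at which 1 of the 3 values shown sits, and so is known only by that limit. Compound 4 `Cc1cccc(-c2nc(CNc3ccc(C(=O)NO)cc3)n(-c3ccccc3)n2)c1` has not yet been measured. The change 3-methylphenyl in place of 4-methoxyphenyl on an aromatic carbon puts 3-methylphenyl in place of 4-methoxyphenyl on an aromatic carbon. Going by the values given here, only one measured step bears on it, and at another place: a 1.4-fold higher number from compound 2 to compound 3 (0.15 log units; within the scatter) brought in the same group on an aromatic nitrogen and stayed within the scatter. Only a small move toward a lower number is therefore expected, with an at least 1.3-fold lower number from compound 1 to compound 4 (0.12 log units; that floor lies within the scatter) as the estimate. In this assay compound 4 is estimated at 15000 nM with an expected range from 7000 nM to 32000 nM as its likely span.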

Compound 4, half-maximal inhibitory concentration: 8710 nM
The estimate for compound 4 lay 1.7-fold (0.24 log units) above the measured number, and the stated range covers the measured number.
By their numbers in this assay, from the lowest: compounds 4, 2 and 3 (each within the scatter of the next). At a limit, above all of these: compound 1.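

Placing 3-methylphenyl in place of 4-methoxyphenyl on this aromatic carbon gives an at least 2.2-fold lower number from compound 1 to compound 4 (0.36 log units; beyond the scatter) in this assay. This is the first step shown that lies beyond the scatter, and it shows that the group at this position can change the number. Its full size remains unknown, as the value of compound 1 is only a limit: the limit of > 20000 nM in this assay, at which 1 of the 4 values shown sits.

The compounds shown leave open what a 4-methylphenyl or 3-methoxyphenyl group would give here, so the methyl and methoxy groups cannot be separated from their places on the phenyl ring. As far as these compounds go, how an amine or a carboxylic acid on that phenyl ring would read also remains open.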